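Changing the quinoline link and what solubility may follow

The compounds below may be only part of what the source reports. "The series", "measured", "known", "first", "only" and "open" are said of these compounds alone.

Compound 1 `CC[C@H]1OC(=O)[C@H](C)[C@@H](O[C@H]2C[C@@](C)(OC)[C@@H](O)[C@H](C)O2)[C@H](C)[C@@H](O[C@@H]2O[C@H](C)C[C@H](N(C)C)[C@H]2OCCCNC(=O)CNc2ccnc3cc(Cl)ccc23)[C@](C)(O)C[C@@H](C)CN(C)[C@H](C)[C@@H](O)[C@]1(C)O` gives in a physicochemical assay for solubility, at pH 4 (a lower number here means a less soluble compound, a higher number a more soluble compound), a value of > 10000 ug/mL, which is a limit of the assay rather than a number.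
Compound 2 `CC[C@H]1OC(=O)[C@H](C)[C@@H](O[C@H]2C[C@@](C)(OC)[C@@H](O)[C@H](C)O2)[C@H](C)[C@@H](O[C@@H]2O[C@H](C)C[C@H](N(C)C)[C@H]2OCCCNc2ccnc3cc(Cl)ccc23)[C@](C)(O)C[C@@H](C)CN(C)[C@H](C)[C@@H](O)[C@]1(C)O` gives in this assay a value of > 10000 ug/mL, again a limit.
Compound 3 `CC[C@H]1OC(=O)[C@H](C)[C@@H](O[C@H]2C[C@@](C)(OC)[C@@H](O)[C@H](C)O2)[C@H](C)[C@@H](O[C@@H]2O[C@H](C)C[C@H](N(C)C)[C@H]2OCCCNc2ccnc3ccccc23)[C@](C)(O)C[C@@H](C)CN(C)[C@H](C)[C@@H](O)[C@]1(C)O` gives in this assay a value of > 10000 ug/mL, a limit as well.

Compound 3 thus stands at the limit of the assay, with no number of its own; the same holds for the two other values shown (the limit of > 10000 ug/mL in this assay, at which 3 of the 3 values shown sit). Among the compounds with values here, the one measured step between compounds that differ in one place, a step that the two limits leave unreadable from compound 2 to compound 3, cannot be sized, since both of its ends are limits.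

Compound 4 `CC[C@H]1OC(=O)[C@H](C)[C@@H](O[C@H]2C[C@@](C)(OC)[C@@H](O)[C@H](C)O2)[C@H](C)[C@@H](O[C@@H]2O[C@H](C)C[C@H](N(C)C)[C@H]2OCCCNCc2ccnc3ccccc23)[C@](C)(O)C[C@@H](C)CN(C)[C@H](C)[C@@H](O)[C@]1(C)O` differs from compound 3 by (quinolin-4-yl)methyl in place of quinolin-4-yl on an amine nitrogen. Within the data shown here, no measured step bears on this change in a readable way, so any expectation rests only on where the three measured compounds sit. Compound 4 is therefore expected to reach the limit once more, with a number no higher from compound 3 to compound 4 (the limit leaves the size open) meaning no step beyond the scatter. The estimate for compound 4 is 10000 ug/mL, with a range from 5000 ug/mL to 20000 ug/mL.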

Compound 4, solubility: > 10000 ug/mL
Compound 4: only a limit was reported; the forecaster's own chance of this, stated with the estimate: 85%; the middle value sits exactly at the limit.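

Compound 4 also gives only a limit, so no size can be read for its steps from compound 2 or compound 3: the limit of > 10000 ug/mL in this assay, at which 4 of the 4 values shown sit.
The compounds shown leave open the actual value of each compound in this assay and whether (quinolin-4-yl)methyl in place of quinolin-4-yl changes that value at all.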